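The compounds below may be only part of what the source reports. "The series", "measured", "known", "first", "only" and "open" are said of these compounds alone.

Measured compounds in a functional assay on HeLa cells (Homo sapiens) for inhibition, read by sulforhodamine B assay, with a stated time of 48 h; on this read-out higher numbers stand for weaker inhibition of growth and lower numbers for stronger inhibition of growth:

Compound 1 `COC(=O)[C@@]1(C)CCC=C2[C@@H]1CC[C@@H](C)[C@]2(C)Cc1c[nH]c2ccc(Br)cc12` gives 10000 nM.
Compound 2 `COC(=O)[C@@]1(C)CCC=C2[C@@H]1CC[C@@H](C)[C@]2(C)Cc1c[nH]c2ccc(OC)cc12` gives 1200 nM.
Compound 3 `COC(=O)[C@@]1(C)CC[C@@H]2C3=C1CC[C@@H](C)[C@]3(C)Cc1c2[nH]c2ccc(Br)cc12` gives 14000 nM.

Compound 1 and compound 2 share one core and differ by methoxy in place of bromo on an aromatic carbon. The step of an 8.3-fold lower number from compound 1 to compound 2 (0.92 log units; beyond the scatter) is the only measured effect of that change in the series. Compound 3 carries a different core; the difference between the two cores is not broken down here. Compound 3 and compound 1 both carry bromo and their values lie within the usual scatter of each other, so nothing is made of their order.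

Compound 4 `COC(=O)[C@@]1(C)CC[C@@H]2C3=C1CC[C@@H](C)[C@]3(C)Cc1c2[nH]c2ccc(OC)cc12` is not yet measured. It relates to compound 3 as compound 2 relates to compound 1: methoxy in place of bromo on an aromatic carbon. The two places are not identical word for word: in compound 1 the ring is part of a fused or bridged system of two rings, in compound 3 of five rings, so this is the same kind of change rather than the same change.

Among the measured compounds shown here, the expectation for compound 4 rests on the single step of an 8.3-fold lower number from compound 1 to compound 2 (0.92 log units; beyond the scatter) and on compound 3 at 14000 nM, giving an estimated step of a 7.0-fold lower number from compound 3 to compound 4 (0.85 log units; beyond the scatter). Compound 4 is accordingly estimated at 2000 nM, with a range from 700 nM to 6000 nM to allow for the change of core, which is supported by one pair only.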

Compound 4, concentration for 50% growth inhibition: 3900 nM
Compound 4: the middle estimate sits 2.0-fold (0.29 log units) below what was measured; low and high end bracket the measured number.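

In this assay, methoxy in place of bromo on the second core gives a 3.6-fold lower number from compound 3 to compound 4 (0.56 log units; beyond the scatter), the same direction as on the core of compound 1. The two steps do not differ measurably, so the change carries across these two cores with its direction kept and no difference in size that can be claimed: the same change on two cores in this assay, an 8.3-fold lower number (0.92 log units; beyond the scatter) from compound 1 to compound 2 and a 3.6-fold lower number (0.56 log units; beyond the scatter) from compound 3 to compound 4, 2.3-fold (0.37 log units) apart, within the scatter of two such steps This rests on two pairs only; it says nothing about other cores, gives no reason for the effect of the change, and shows growth inhibition in this one cell line alone.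

The compounds shown leave open what other groups would do at this aromatic carbon, such as hydrogen, an amine or a longer chain like ethoxy, and whether any of them would go beyond methoxy on either core. On these data alone, all four compounds also keep the methyl ester, so the effect of a carboxylic acid or an amide in its place remains open.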